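From an Anilino Group to Azetidine: Compound 4

This account rests on a few compounds, and the source may have more. Where it says the series, first, only, none or still open, it means among the compounds named here.

Measured compounds in a functional assay on HeLa cells (Homo sapiens) for inhibition, read by sulforhodamine B assay; a higher number here means a weaker inhibitor, a lower number a stronger inhibitor:
compound 1 `O=C1C=C(Nc2ccc(I)cc2)C(=O)c2c1nc1n2[C@H]2OC[C@@H](O)[C@H]2OC1`: compound 1 gives 4070 nM
compound 2 `COc1ccc(NC2=CC(=O)c3c(nc4n3[C@H]3OC[C@@H](O)[C@H]3OC4)C2=O)cc1`: compound 2 gives only the limit > 8000 nM
compound 3 `CCc1ccc(NC2=CC(=O)c3nc4n(c3C2=O)[C@H]2OC[C@@H](O)[C@H]2OC4)cc1`: compound 3 gives 3990 nM

Among the measured compounds shown here, compound 2 stands apart from the other two, since in this assay its result is a limit of the assay and not a number; it is the one compound of the three sitting at the limit of > 8000 nM in this assay, at which 1 of the 3 values shown sits. Compound 4 `O=C1C(N2CCC2)=CC(=O)c2c1nc1n2[C@H]2OC[C@@H](O)[C@H]2OC1` differs from compound 2 in one place: azetidin-1-yl in place of (4-methoxyphenyl)amino on a double-bonded ring carbon. For the measured compounds named here, the only measured step, a 1.0-fold lower number from compound 1 to compound 3 (0.01 log units; within the scatter), swaps one group on the aromatic ring for another and leaves that ring in place, so it does not bear on the loss of the whole (4-methoxyphenyl)amino group. Going by the values given here, no measured step therefore informs the change to compound 4. Starting from a limit, compound 4 is expected to give 10000 nM, within 3000 nM to 30000 nM. The step that this estimate means, a step that the limit leaves unreadable from compound 2 to compound 4, is expected to be no more than the scatter allows to be told from a limit.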

Compound 4, half-maximal inhibitory concentration: > 16000 nM
Compound 4 was reported as a limit (the forecaster's own chance of this, stated with the estimate: 55%); middle value at least 1.6-fold (0.20 log units) from the limit.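

In this assay compound 2 gives > 8000 nM, a limit and not a number. Among the compounds shown here, compound 4 gives > 16000 nM, also a limit, so no step from compound 2 to compound 4 can be read. The compounds shown leave open how azetidin-1-yl compares with (4-methoxyphenyl)amino on the shared core.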